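The compounds below may be only part of what the source reports. "The series", "measured", "known", "first", "only" and "open" are said of these compounds alone.

Measured compounds:
compound 1 `COc1cc(-c2nnc3n2NC(c2ccco2)C(C(=O)c2ccc(Cl)cc2)S3)cc(OC)c1OC` — 78600 nM
compound 2 `COc1cc(-c2nnc3n2NC(c2ccco2)C(C(=O)c2ccc(F)c(F)c2)S3)cc(OC)c1OC` — 52400 nM

In a functional assay on HepG2 cells (Homo sapiens) for cytotoxicity, read by MTT assay, with a stated time of 48 h (on this read-out higher numbers stand for weaker inhibition and lower numbers for stronger inhibition), compound 2 gives 52400 nM, and compound 1 gives 78600 nM; the two values lie within the scatter of each other, so neither compound can be called weaker or stronger. Among the measured compounds shown here, the only step available, a 1.5-fold lower number from compound 1 to compound 2 (0.18 log units; within the scatter), changed the group on the carbonyl carbon. Compound 3 `COc1cc(-c2nnc3n2NC(c2ccco2)C(C(=O)c2ccc(-c4ccccc4)cc2)S3)cc(OC)c1OC` arises from compound 2 by 4-phenylphenyl in place of 3,4-difluorophenyl on a carbonyl carbon. For the measured compounds named here, no measured pair shows this change, and the one step on the same carbonyl carbon stayed within the scatter, so compound 3 is expected to give 55000 nM (range 20000 nM to 150000 nM), a step of a 1.0-fold higher number from compound 2 to compound 3 (0.02 log units; within the scatter) that is expected to stay within the scatter.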

Compound 3, half-maximal inhibitory concentration: > 100000 nM
Compound 3: no number, only a limit (the forecaster's own chance of this, stated with the estimate: 15%); middle value at least 1.8-fold (0.25 log units) from the limit.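

In this assay compound 3 gives > 100000 nM as a limit of the assay and not as a number. The step of an at least 1.9-fold higher number from compound 2 to compound 3 (0.28 log units; that floor lies within the scatter) for 4-phenylphenyl in place of 3,4-difluorophenyl and the step of an at least 1.2-fold higher number from compound 1 to compound 3 (0.10 log units; that floor lies within the scatter) for phenyl in place of chloro are floors only, so neither sets compound 3 apart. What is new is that 4-phenylphenyl on this carbonyl carbon yields no readable number, whereas the halogen-bearing groups of compound 1 and compound 2 do. Still open, going by these compounds, are the true size of both steps and how a 4-aminophenyl or 4-carboxyphenyl group would read at this position.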